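Carbamoyl in Place of Chloro on a Shared Core

The source may hold more compounds than are shown below. What is called first, only, known or untested is meant among the compounds shown, and "the series" means these compounds.

Measured compounds:
compound 1 `Cn1cc(-c2cnc3[nH]cc(-c4ccc(Cl)cc4)c3c2)cn1`: 800 nM
compound 2 `Cn1cc(-c2cnc3[nH]cc(-c4ccccc4F)c3c2)cn1`: 14000 nM

In a physicochemical assay for solubility, read by LC-MS, in phosphate buffer, measured as thermodynamic solubility, with a stated time of 24 h, at pH 7.4 (a higher number here means a more soluble compound, a lower number a less soluble compound), compound 1 gives 800 nM, the lowest of the two numbers; the nearest, compound 2, gives 14000 nM. Within the data shown here, the one measured step, an 18-fold higher number from compound 1 to compound 2 (1.24 log units; beyond the scatter), is large. Compound 3 `Cn1cc(-c2cnc3[nH]cc(-c4ccc(C(N)=O)cc4)c3c2)cn1` differs from compound 1 by carbamoyl in place of chloro on an aromatic carbon, a change at a different place and of a different kind, so the measured step bears on it only loosely. A rise beyond the scatter is nevertheless expected, a 15-fold higher number from compound 1 to compound 3 (1.18 log units; beyond the scatter). Compound 3 is estimated at 12000 nM, within a range from 2500 nM to 60000 nM.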

Compound 3, solubility: 3000 nM
The estimate for compound 3 lay 4.0-fold (0.60 log units) above the measured number, and the stated range covers the measured number.
By their numbers in this assay, from the lowest: compound 1; then compound 3; then compound 2.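

With the substituent kept on the same aromatic carbon, para to a large group, carbamoyl in place of chloro gives a 3.8-fold higher number from compound 1 to compound 3 (0.57 log units; beyond the scatter) in this assay. Unlike the earlier step, this one changes only the group at this place, so it shows that an exchange of group alone moves the number beyond the scatter here. Nothing available accounts for this step. The compounds shown leave open whether an amine or a carboxylic acid on this same carbon would give a larger or smaller step from compound 1.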